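Dropping the fluoro: from compound 3 to compound 4

The compounds below may be only part of what the source reports. "The series", "measured", "known", "first", "only" and "open" are said of these compounds alone.

Compound 1 `O=C(COc1ccc(C(=O)/C=C/c2ccccc2Cl)cc1)N[C@H]1CCOC1=O` gives 17400 nM in a functional assay on MCF7 cells (Homo sapiens) for antiproliferative activity, read by MTT assay, with a stated time of 72 h; on this read-out higher numbers stand for weaker inhibition and lower numbers for stronger inhibition. Compound 2 `O=C(COc1ccc(C(=O)/C=C/c2ccccc2Br)cc1)N[C@H]1CCOC1=O` gives 15300 nM in this assay, which is a 1.1-fold lower number from compound 1 to compound 2 (0.06 log units; within the scatter). Compound 3 `O=C(COc1ccc(C(=O)/C=C/c2cccc(F)c2)cc1)N[C@H]1CCOC1=O` reaches only a limit of this assay, > 64000 nM. That limit, (the limit of > 64000 nM in this assay, at which 1 of the 3 values shown sits), makes compound 3 the weakest of the three, seen as an at least 3.6-fold higher number from compound 1 to compound 3 (0.56 log units; beyond the scatter) and an at least 4.1-fold higher number from compound 2 to compound 3 (0.62 log units; beyond the scatter).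

Compound 4 `O=C(COc1ccc(C(=O)/C=C/c2ccccc2)cc1)N[C@H]1CCOC1=O` differs from compound 3 by hydrogen in place of fluoro on an aromatic carbon. Among the compounds with values here, no measured step removes a fluoro on its own; the two steps into compound 3 only show that the 3-fluorophenyl falls well behind 2-chlorophenyl and 2-bromophenyl. Compound 4, lacking any halogen, is expected to stay near compound 3, with a fair chance of another limit, so the expected step is an at least 1.2-fold lower number from compound 3 to compound 4 (0.10 log units; that floor lies within the scatter). The estimate for compound 4 in this assay is 50000 nM, between 15000 nM and 120000 nM.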

Compound 4, half-maximal inhibitory concentration: > 64000 nM
Compound 4 was reported as a limit; the forecaster's own chance of this, stated with the estimate: 50%; middle value at least 1.2-fold (0.10 log units) away from the limit.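

Compound 4 reaches only a limit in this assay. Hydrogen in place of chloro gives an at least 3.6-fold higher number from compound 1 to compound 4 (0.56 log units; beyond the scatter), and hydrogen in place of bromo gives an at least 4.1-fold higher number from compound 2 to compound 4 (0.62 log units; beyond the scatter), so among the compounds shown a readable value comes only with the 2-chlorophenyl and the 2-bromophenyl, not with the unsubstituted phenyl. The step from compound 3 to compound 4 cannot be read, because both sit at a limit: the limit of > 64000 nM in this assay, at which 2 of the 4 values shown sit.

Halogen kind and ring position remain confounded, since chloro and bromo appear only in the 2-substituted phenyls and fluoro only in the 3-fluorophenyl. Still open, from the compounds shown here alone, is how a 2-fluorophenyl, a 3-chlorophenyl or a 2-methoxyphenyl would stand in this assay.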